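The source may report more compounds than this note shows. Statements on the series, on what has been measured and on what is new or still open speak of the compounds shown alone.

Working notes on the series. The shared core carries a benzyloxyphenyl imine joined to a substituted phenol. Compound 1 `Oc1ccc(/C=N/c2ccc(OCc3ccccc3)cc2)c(O)c1` gives 6780 nM in an assay on isolated protein for inhibition of Amine oxidase [flavin-containing] B (Homo sapiens), read by fluorescence and Amplex Red, with stated times of 15 min and 20 min; a higher number here means a weaker inhibitor, a lower number a stronger inhibitor. Compound 2 `Cc1ccc(/C=N/c2ccc(OCc3ccccc3)cc2)c(O)c1` gives 24400 nM and stands highest of the three numbers; compound 3 `Oc1ccc(/C=N/c2ccc(OCc3ccccc3)cc2)c(O)c1O` gives 1730 nM, the lowest. The two measured steps both start from compound 1: a 3.6-fold higher number from compound 1 to compound 2 (0.56 log units; beyond the scatter) and a 3.9-fold lower number from compound 1 to compound 3 (0.59 log units; beyond the scatter).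

Compound 4 `Oc1ccccc1/C=N/c1ccc(OCc2ccccc2)cc1` is not yet measured. It differs from compound 2 as hydrogen in place of methyl on an aromatic carbon: the 2-hydroxy-4-methylphenyl group becomes 2-hydroxyphenyl. Among the measured compounds shown here, no measured step swaps methyl for hydrogen directly, so the bearing is indirect: the step from compound 1 to compound 2 shows that the methyl sits on a weaker compound than the hydroxy, and the step from compound 1 to compound 3 shows that more hydroxy groups on that ring go with stronger inhibition. Taking the methyl away is expected to move the number down, by a 2.0-fold lower number from compound 2 to compound 4 (0.31 log units; beyond the scatter), landing between compound 2 and compound 1 rather than matching compound 1. Compound 4 is therefore estimated at 12000 nM, with a range of 4000 nM to 40000 nM.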

Compound 4, half-maximal inhibitory concentration: 25100 nM
For compound 4 the middle estimate is 2.1-fold (0.32 log units) below the measured one, within the range that was stated.
By their numbers in this assay, from the lowest: compound 3; then compound 1; then compounds 2 and 4 (each within the scatter of the next).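

At the position para to a large group and meta to a hydroxy group, a 1.0-fold higher number from compound 2 to compound 4 (0.01 log units; within the scatter) in this assay, so methyl and hydrogen cannot be told apart there. Of the three groups compared at this position, only hydroxy stands apart: a 3.7-fold higher number from compound 1 to compound 4 (0.57 log units; beyond the scatter), and with methyl in its place the step is a 3.6-fold higher number from compound 1 to compound 2 (0.56 log units; beyond the scatter). Nothing measured here gives a reason for this reading.

From the compounds shown here alone, it remains open whether an amine, a methoxy group or a fluorine at this position would read like hydroxy or like the hydrogen and methyl pair. Also open, going by these compounds, is whether the further hydroxy of compound 3 would bring a similar change on the core of compound 4, which has no hydroxy at the position examined here.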